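Chloro for fluoro on the triazole-bound phenyl of compound 3

A few compounds are considered here, and "the series" means these few. Any claim that something is new, unique, unknown or untested is made for them only; others in the source may bear on it.

Measured so far in an ADME assay on WI-38 cells (Homo sapiens) for antiproliferative activity, read by MTT assay, with a stated time of 72 h; on this read-out higher numbers stand for weaker inhibition and lower numbers for stronger inhibition:
- compound 1, `CCCCCc1ccc(C#Cc2c(-c3ccc(CCCCC)cc3)oc3nc(=O)n(Cc4cn(-c5ccc(Cl)cc5)nn4)cc23)cc1`: > 100000 nM (an assay limit, not a number)
- compound 2, `CCCCCCC#Cc1c(CCCCCC)oc2nc(=O)n(Cc3cn(-c4ccc(F)cc4)nn3)cc12`: > 100000 nM (an assay limit, not a number)
- compound 3, `O=c1nc2oc(CCCCl)cc2cn1Cc1cn(-c2ccc(F)cc2)nn1`: < 10 nM (an assay limit, not a number)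

Compound 3 sits at the limit of < 10 nM in this assay, at which 1 of the 3 values shown sits, the strong end of what this assay reports. Within the data shown here, the two other compounds sit at the limit of > 100000 nM in this assay, at which 2 of the 3 values shown sit, so none of the three values shown is an actual number, and no step between measured compounds can be computed from them. Compound 3 therefore stands apart from compound 1 and compound 2 only in that its limit lies at the opposite end of the range.

Compound 4, `O=c1nc2oc(CCCCl)cc2cn1Cc1cn(-c2ccc(Cl)cc2)nn1`, keeps the whole of compound 3 and differs from it in one place: chloro in place of fluoro on an aromatic carbon, which, cut one bond further out, reads 4-fluorophenyl to 4-chlorophenyl. Among the measured compounds shown here, no measured pair shows what such an exchange does in this assay, so the expectation for the step from compound 3 to compound 4 is none beyond the usual scatter, and it is estimated as a step that the limit leaves unreadable from compound 3 to compound 4. Compound 4 is accordingly expected to give about 7 nM in this assay, within a range of 1.5 nM to 35 nM, and quite possibly again only the limit.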

Compound 4, half-maximal inhibitory concentration: 72500 nM
The estimate for compound 4 lay 10000-fold (4.02 log units) below the measured number; the measured number lies above the stated range.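

In this assay, chloro in place of fluoro on an aromatic carbon, para to a large group, gives an at least 7200-fold higher number from compound 3 to compound 4 (3.86 log units; beyond the scatter), so with the rest of the molecule unchanged, this single halogen exchange on the ring separates the two compounds. Among these compounds, compound 1 carries chloro and compound 2 carries fluoro on the same ring, but they differ from each other and from compound 3 in more than one place, so only this pair isolates the halogen. The size of the step is only a lower bound, as the value for compound 3 is a limit of the assay and not a number: the limit of < 10 nM in this assay, at which 1 of the 4 values shown sits.

This single pair cannot say whether the same exchange would have a comparable result on a core carrying other chains, such as the longer chains of compound 1 and compound 2. It also leaves open what bromo, methoxy, an amine or a carboxylic acid would give on that same aromatic carbon, and so whether fluoro is a special case or chloro is.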